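Swapping one aromatic group on a shared core

The source may hold more compounds than are shown below. What is called first, only, known or untested is meant among the compounds shown, and "the series" means these compounds.

Measured so far in a functional assay on K562/Adr cells (Homo sapiens) for inhibition, read by MTT assay, with a stated time of 48 h; a higher number here means a weaker inhibitor, a lower number a stronger inhibitor:
- compound 1 (`CS(=O)(=O)Nc1ccc(-c2cn([C@@H]3CN[C@H](C(=O)Nc4ccc(Cl)c(C(F)(F)F)c4)C3)nn2)cn1`) gives 4720 nM
- compound 2 (`O=C(Nc1n[nH]c2cc(-c3cn([C@@H]4CN[C@H](C(=O)Nc5ccc(Cl)c(C(F)(F)F)c5)C4)nn3)ccc12)C1CC1`) gives 9570 nM

Among the compounds with values here, only two compounds have numbers, and compound 1 holds the lower one, which makes it the stronger inhibitor of the pair. The gap up to compound 2 lies just beyond the usual scatter of repeated measurements.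

The next compound, compound 3 (`Nc1nc2ccc(-c3cn([C@@H]4CN[C@H](C(=O)Nc5ccc(Cl)c(C(F)(F)F)c5)C4)nn3)nc2s1`), has not yet been measured. It keeps the core of compound 1 and changes one group, on an aromatic carbon of a five-membered aromatic ring with 3 nitrogen: a group of 10 heavy atoms (6 carbon, 3 nitrogen, 1 sulfur; one five-membered aromatic ring with 2 hetero atoms, one six-membered aromatic ring with 1 hetero atom) in place of a group of 11 heavy atoms (6 carbon, 2 nitrogen, 2 oxygen, 1 sulfur; one six-membered aromatic ring with 1 hetero atom), on an aromatic carbon. The 6-(methanesulfonamido)pyridin-3-yl group leaves, and a group with two fused aromatic rings enters.

Within the data shown here, no measured pair shows this exact swap. Still, the two known compounds differ in the group at this same place, and compound 1 at 4720 nM and compound 2 at 9570 nM stay fairly close. A small move towards a higher number, and so a slightly weaker inhibitor, is therefore expected, probably none beyond the scatter. The expected size is a 1.3-fold higher number from compound 1 to compound 3 (0.10 log units; within the scatter). For compound 3 the estimated value in this assay is 6000 nM, within a range from 2500 nM to 15000 nM.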

Compound 3, half-maximal inhibitory concentration: 187000 nM
Compound 3: the middle estimate sits 31-fold (1.49 log units) below what was measured, and the stated range ends below it.
By their numbers in this assay, from the lowest: compound 1; then compound 2; then compound 3.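

This result shows that the group on this aromatic carbon of the five-membered ring can decide much of the activity: in this assay, replacing the 6-(methanesulfonamido)pyridin-3-yl group with the group bearing two fused aromatic rings gives a 40-fold higher number from compound 1 to compound 3 (1.60 log units; beyond the scatter) and thus a much weaker inhibitor. The two measured groups that came first gave no sign of so large a loss, since compound 1 gives 4720 nM and compound 2 gives 9570 nM in this assay. The counts also do little to separate the leaving and entering groups, with close heavy-atom counts and one hydrogen-bond donor each, so these simple counts do not track the change, and nothing measured here explains the loss.

As far as these compounds go, it remains open whether the loss belongs to the two fused rings as a whole or to the amine on them, which a fused pair without that amine could help to separate. From the compounds shown here alone, it is also open how a plain phenyl ring, or a pyridine carrying a carboxylic acid, would behave at this place on the shared core.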